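A Second Methyl on the Pyrazole of Compound 2

The source may hold more compounds than are shown below. What is called first, only, known or untested is meant among the compounds shown, and "the series" means these compounds.

Compound 1 `C[C@@H]1CCCN1c1c(C#N)c2c(N)nc(Nc3cn[nH]c3)nc2n1C` gives 0.4 nM in an assay on isolated protein for binding affinity to Leucine-rich repeat serine/threonine-protein kinase 2 variant G2019S (Homo sapiens), read by TR-FRET and LanthaScreen, with a stated time of 2 h; a lower number here means a stronger inhibitor, a higher number a weaker inhibitor. Compound 2 `C[C@@H]1CCCN1c1c(C#N)c2c(N)nc(Nc3cnn(C)c3)nc2n1C` gives 0.3 nM.

Within the data shown here, on the numbers measured so far compound 2 has the lower value, but only by a 1.3-fold lower number from compound 1 to compound 2 (0.12 log units; within the scatter), a step within the scatter, so the two compounds are not distinguished. Compound 3 `Cc1nn(C)cc1Nc1nc(N)c2c(C#N)c(N3CCC[C@H]3C)n(C)c2n1` differs from compound 2 by methyl in place of hydrogen on an aromatic carbon. Among the measured compounds shown here, the one measured step added a methyl on a ring nitrogen of the same pyrazole and stayed within the scatter; no measured step adds a methyl on a ring carbon, so guidance is loose. A step of about a 1.7-fold higher number from compound 2 to compound 3 (0.22 log units; within the scatter) is expected, not beyond the scatter. Compound 3 is therefore estimated at 0.5 nM, within 0.15 nM to 2 nM.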

Compound 3, inhibition constant: 2 nM
Compound 3: the middle estimate sits 4.0-fold (0.60 log units) below what was measured; measured number inside the range.
By their numbers in this assay, from the lowest: compounds 2 and 1 (each within the scatter of the next); then compound 3.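

On this pyrazole, the position of the methyl matters in this assay: the methyl on the ring nitrogen stayed within the scatter (a 1.3-fold lower number from compound 1 to compound 2 (0.12 log units; within the scatter)), while the one on the aromatic carbon next to the ring nitrogen goes beyond it (a 6.7-fold higher number from compound 2 to compound 3 (0.82 log units; beyond the scatter)). With both methyl groups in place, the comparison with the unsubstituted pyrazole also lies beyond the scatter (a 5.0-fold higher number from compound 1 to compound 3 (0.70 log units; beyond the scatter)). No evidence here accounts for this difference between the two positions. From the compounds shown here alone, what an ethyl, a methoxy or a chlorine on this same carbon would do remains open.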